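Positional shift of the trifluoromethyl group on the benzyl arm

This account rests on a few compounds, and the source may have more. Where it says the series, first, only, none or still open, it means among the compounds named here.

Compound 1 `COc1ccc([C@@H]2CC(=O)c3c(O)cc(OCc4cn(Cc5ccc(C(F)(F)F)cc5)nn4)cc3O2)cc1O` gives 17700 nM in a functional assay on RAW264.7 cells (Mus musculus) for inhibition, read by Griess assay, with stated times of 2 h and 24 h (on this read-out higher numbers stand for weaker inhibition and lower numbers for stronger inhibition), the second highest of the three numbers in hand. Among the measured compounds shown here, compound 3 `C#CCOc1cc(O)c2c(c1)O[C@H](c1ccc(OC)c(O)c1)C/C2=N\O` gives 19100 nM, within the scatter of compound 1, while compound 2 `CCn1cc(COc2cc(O)c3c(c2)O[C@H](c2ccc(OC)c(O)c2)C/C3=N\O)nn1` gives 3140 nM, the only value clearly apart. Compound 4 `COc1ccc([C@@H]2CC(=O)c3c(O)cc(OCc4cn(Cc5ccccc5C(F)(F)F)nn4)cc3O2)cc1O` differs from compound 1 by 2-(trifluoromethyl)phenyl in place of 4-(trifluoromethyl)phenyl on a saturated chain carbon bound to an aromatic nitrogen. For the measured compounds named here, the one measured step, a 6.1-fold higher number from compound 2 to compound 3 (0.78 log units; beyond the scatter), concerns the group on the oxygen-bound chain carbon, not the benzyl arm, so no measured step bears on the change in hand. With nothing to point in either direction, compound 4 is expected to stay within scatter of compound 1, a step of a 1.0-fold lower number from compound 1 to compound 4 (0.02 log units; within the scatter). Compound 4 is therefore estimated at 17000 nM, in the range 6000 nM to 48000 nM.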

Compound 4, half-maximal inhibitory concentration: 12500 nM
The estimate for compound 4 lay 1.4-fold (0.13 log units) above the measured number, within the range that was stated.
By their numbers in this assay, from the lowest: compound 2; then compounds 4, 1 and 3 (each within the scatter of the next).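

Within this assay, a 1.4-fold lower number from compound 1 to compound 4 (0.15 log units; within the scatter) is the first measured step on the benzyl arm. In this pair, the read-out does not separate 2-(trifluoromethyl)phenyl from 4-(trifluoromethyl)phenyl on a saturated chain carbon bound to an aromatic nitrogen. No measurement in hand accounts for this result.

Still open, on these data alone, is whether a benzyl arm carrying a carboxylic acid or an amine in place of trifluoromethyl would stand apart from compound 1. Also open, as far as these compounds go, is whether 2-(trifluoromethyl)benzyl would read the same on the core of compound 2.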